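Thiazolyl replacement for the trifluorophenyl group on the core

This account rests on a few compounds, and the source may have more. Where it says the series, first, only, none or still open, it means among the compounds named here.

Going by the values given here, compound 1 `O=C(O)CNC(=O)c1c(O)c2c(n(Cc3cc(F)c(F)cc3F)c1=O)COC2` is the stronger of the two compounds measured so far. In an assay on Sf9 cells for inhibition of prolyl hydroxylase EGLN2 (Homo sapiens), read by TR-FRET, with stated times of 30 min and 2 h (on this read-out higher numbers stand for weaker inhibition and lower numbers for stronger inhibition), compound 1 gives 3.1 nM. Compound 2 `O=C(O)CNC(=O)c1c(O)c2c(n(Cc3cnc(C(F)(F)F)nc3)c1=O)COC2`, which carries a trifluoromethyl-substituted pyrimidinyl group on the same saturated chain carbon, gives 11 nM in this assay; the gap between compound 1 and compound 2 lies beyond the usual scatter. The change from compound 1 to the not yet measured compound 3 `O=C(O)CNC(=O)c1c(O)c2c(n(Cc3nc(C(F)(F)F)cs3)c1=O)COC2` is 4-(trifluoromethyl)-1,3-thiazol-2-yl in place of 2,4,5-trifluorophenyl on a saturated chain carbon bound to an aromatic nitrogen. Among the compounds with values here, no pair shows this exact exchange, so its size is open. Compound 2 shows that a heteroaryl group in this place can give a weaker number than compound 1, and a small loss is therefore expected, with the step of a 1.9-fold higher number from compound 1 to compound 3 (0.29 log units; within the scatter) likely close to the scatter. In this assay compound 3 is expected to give about 6 nM, with a range from 2.5 nM to 15 nM.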

Compound 3, half-maximal inhibitory concentration: 3.7 nM
Compound 3: the middle estimate sits 1.6-fold (0.21 log units) above what was measured; measured number inside the range.
By their numbers in this assay, from the lowest: compounds 1 and 3 (each within the scatter of the next); then compound 2.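

In this assay, 4-(trifluoromethyl)-1,3-thiazol-2-yl in place of 2,4,5-trifluorophenyl on a saturated chain carbon bound to an aromatic nitrogen gives a 1.2-fold higher number from compound 1 to compound 3 (0.08 log units; within the scatter), so the numbers of the two compounds cannot be told apart. Going by these compounds alone, this place therefore accepts a five-membered aromatic ring with 2 hetero atoms, and compound 2 at 11 nM no longer stands as the only reading for a heteroaryl group here. No measurement on these groups is at hand to account for this result.

The compounds shown leave open what the trifluoromethyl group contributes, which a plain 1,3-thiazol-2-yl or a methyl group in its place would address. Also open, as far as these compounds go, is whether the result holds when the carboxylic acid sits on a longer chain.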